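Trifluoromethyl in Place of Chloro on the Fused Core

This account rests on a few compounds, and the source may have more. Where it says the series, first, only, none or still open, it means among the compounds named here.

Among the measured compounds shown here, compound 2 `Clc1cc(-c2ccn3c(CC4CC4)nnc3c2Cl)ccc1OC1CCOCC1` gives 28.1 nM in an assay on cells for binding affinity to metabotropic glutamate receptor 2 (Homo sapiens), read by scintillation proximity assay (a lower number here means tighter binding, a higher number weaker binding), the higher of the two numbers known here. For the measured compounds named here, compound 1 `CC(C)Nc1ccc(-c2ccn3c(CC4CC4)nnc3c2C(F)(F)F)cc1Cl` gives 3.4 nM in this assay, but it differs from compound 2 in two places, so no single step connects them. Compound 3 `FC(F)(F)c1c(-c2ccc(OC3CCOCC3)c(Cl)c2)ccn2c(CC3CC3)nnc12` departs from compound 2 by trifluoromethyl in place of chloro on an aromatic carbon. Going by the values given here, no measured step of this kind exists in the set. The chemist expects a modest tightening, so that a 2.3-fold lower number from compound 2 to compound 3 (0.37 log units; beyond the scatter) is the estimated step in this assay. Compound 3 is therefore estimated at 12 nM, with a range from 4 nM to 35 nM.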

Compound 3, dissociation constant: 12.3 nM
For compound 3 the middle estimate is 1.0-fold (0.01 log units) below the measured one; the range from low to high includes it.
By their numbers in this assay, from the lowest: compound 1; then compound 3; then compound 2.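

In this assay, among the compounds shown here, trifluoromethyl in place of chloro on this aromatic carbon gives a 2.3-fold lower number from compound 2 to compound 3 (0.36 log units; beyond the scatter), the first single-change reading at this position. With trifluoromethyl held fixed, (oxan-4-yl)oxy in place of isopropylamino gives a 3.6-fold higher number from compound 1 to compound 3 (0.56 log units; beyond the scatter), so the number also moves with the group at that second place. Nothing measured here bears on why either step occurs. The compounds shown leave open how a nitrile or a methyl group would read on the same carbon, and whether the isopropylamino change would give a similar step with chloro on the core.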